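A Chloro Swap on the Longer-Lived Compound

The source may report more compounds than this note shows. Statements on the series, on what has been measured and on what is new or still open speak of the compounds shown alone.

Within the data shown here, in an ADME assay on S9 fraction from liver (Mus musculus, strain ICR/CD-1) for metabolic stability, read by LC-MS, using NADPH, with a stated time of 5 min, tested at 2 uM (on this read-out lower numbers stand for a shorter-lived compound and higher numbers for a longer-lived compound), compound 1 (`COc1ccc(-c2cccc(S(=O)(=O)N3CCC(N4CCC(C)CC4)CC3)c2)cc1`) gives 2.4 h and holds the higher of the two numbers so far. Compound 2 (`CC1CCN(C2CCN(S(=O)(=O)c3ccc(Br)c(Cl)c3)CC2)CC1`) gives 0.717 h and sits lower by more than the usual scatter. Compound 3 (`CC1CCN(C2CCN(S(=O)(=O)c3cccc(-c4ccc(Cl)cc4)c3)CC2)CC1`) changes one group of compound 1: chloro in place of methoxy on an aromatic carbon in a swap of 4-methoxyphenyl to 4-chlorophenyl, with chloro in place of methoxy on an aromatic carbon. Among the measured compounds shown here, no measured pair shows this swap on its own. In this assay the estimated step of a 1.1-fold lower number from compound 1 to compound 3 (0.04 log units; within the scatter) is expected to stay within the scatter. The half-life expected for compound 3 is 2.2 h (with an estimated range of 0.9 h to 5 h).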

Compound 3, half-life: 2.45 h
Beside the measured number, compound 3's estimate is 1.1-fold (0.05 log units) below it, and the stated range covers the measured number.
By their numbers in this assay, from the lowest: compound 2; then compounds 1 and 3 (each within the scatter of the next).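

In this assay chloro in place of methoxy on the aromatic carbon para to a large group gives a 1.0-fold higher number from compound 1 to compound 3 (0.01 log units; within the scatter) and so leaves the half-life unchanged within the scatter. For this pair, the methoxy group is therefore not needed to keep the half-life of compound 1, and a lone chloro does as well. No measurement shown here explains why the two groups match. As far as these compounds go, whether an amine, a carboxylic acid or a trifluoromethyl group at this position would also keep the half-life remains open. So does whether this swap behaves the same way on another core.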